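The compounds below may be only part of what the source reports. "The series", "measured", "known", "first", "only" and "open" are said of these compounds alone.

Compound 1 `O=C(CCCCC(S)CCS)Nc1ccccc1Cl`: 7.72%
Compound 2 `O=C(CCCCC(S)CCS)Nc1ccc(OC(F)(F)F)cc1`: 0.56%
Compound 3 `CC(=O)SCCC(CCCCC(=O)Nc1ccccc1Cl)SC(C)=O`: "not active" (no number reported)

All three compounds were tested in a functional assay on HO8910 cells (Homo sapiens) for inhibition, read by MTT assay, with a stated time of 24 h, tested at 1 ug/mL; a lower number here means less inhibition of growth, a higher number more inhibition of growth at the concentration tested. Two of them received a number, and those two readings lie within the usual scatter of each other. For the measured compounds named here, compound 3 has no number at all: the result for compound 3 is simply "not active" (no number reported), so it cannot be placed exactly on the scale and no step can be calculated from it.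

The next compound to be tested is compound 4 `CC(=O)SCCC(CCCCC(=O)Nc1ccc(Cl)cc1)SC(C)=O`, which has the same atoms as compound 3, joined differently: 4-chlorophenyl in place of 2-chlorophenyl on an amide-type nitrogen. The chlorine stays on the ring, and only the name of the group changes, with 4-chlorophenyl in place of 2-chlorophenyl on an amide-type nitrogen.

Going by the values given here, no measured pair shows this change on its own, so the data give no direct guide to its size. The expectation rests on compound 3, reported as "not active" (no number reported), and on the small reading of compound 1 at 7.72%. No step beyond the scatter is expected in this assay, in either direction, and a second "not active" report would be no surprise. If a number is reported, the estimate for compound 4 is 3%, with an expected range from 0% to 12%.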

Compound 4, percent growth inhibition at one concentration: 0.35%
Beside the measured number, compound 4's estimate is 2.7 percentage points above it, within the range that was stated.
By their numbers in this assay, from the lowest: compounds 4, 2 and 1 (each within the scatter of the next).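

No step can be read from compound 3 to compound 4: compound 4 gives 0.35% while compound 3 has only a "not active" report, with no number. No measurement shown offers an explanation for these readings. Going by these compounds, whether 4-chlorophenyl in place of 2-chlorophenyl changes growth inhibition by any measurable amount stays open.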